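Removing a Methyl from a Ring Nitrogen in Two Cores

This account rests on a few compounds, and the source may have more. Where it says the series, first, only, none or still open, it means among the compounds named here.

Compound 1 `CN(C)c1nccc2c1ncn2C1O[C@H](CO)[C@@H](O)[C@H]1O` and compound 3 `CNc1nccc2c1ncn2C1O[C@H](CO)[C@@H](O)[C@H]1O` share a core; in a functional assay (Homo sapiens) for inhibition of Nucleic Acid, tested at 100 uM (on this read-out higher numbers stand for more inhibition at the one concentration tested (going by the name of the read-out) and lower numbers for less inhibition), compound 1 gives 0% and compound 3 gives 8%. The change between them is hydrogen in place of methyl on a nitrogen on an aromatic ring and it made a step of a number 8 percentage points higher from compound 1 to compound 3 (within the scatter). Compound 2 `CNc1[nH]ccc2ncnc1-2` rests on a different core, and the difference between the two cores is not broken down here; in this assay compound 2 gives 18%. Compound 4 `Nc1[nH]ccc2ncnc1-2` is not yet measured. It differs from compound 2 by hydrogen in place of methyl on a nitrogen on an aromatic ring, the same kind of change as before, though here the nitrogen's other neighbours are only an aromatic carbon rather than an aromatic carbon and a saturated chain carbon. Because the earlier step was a number 8 percentage points higher from compound 1 to compound 3 (within the scatter), a similarly small step of a number 4 percentage points higher from compound 2 to compound 4 (within the scatter) is expected from compound 2 to compound 4. Compound 4 is thus estimated at 22%, between 5% and 40%.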

Compound 4, a percentage reported as inhibition, at one concentration (the size of the read-out at that concentration, not a potency): 60%
Estimate against measurement, compound 4: 38 percentage points below, and the stated range ends below it.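

In this assay, hydrogen in place of methyl on a nitrogen on an aromatic ring gave a number 42 percentage points higher from compound 2 to compound 4 (beyond the scatter). The size of this step did not carry over from one core to the other: the same change on two cores in this assay, a number 8 percentage points higher (within the scatter) from compound 1 to compound 3 and a number 42 percentage points higher (beyond the scatter) from compound 2 to compound 4, 34 percentage points apart, beyond the scatter of two such steps This does not show why the two steps differ, since the pairs differ both in their core and in what else the nitrogen carries, and two pairs cannot separate these or give a rule for other cores.

The compounds shown leave open how the core of compound 1 behaves with a plain amino group in that place. They also leave open how either core responds to a longer chain such as ethyl, or to an acetyl group, on that nitrogen.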